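A Halogen Swap at the Assay Limit

The source may hold more compounds than are shown below. What is called first, only, known or untested is meant among the compounds shown, and "the series" means these compounds.

Measured in a functional assay on U-251 cells (Homo sapiens); on this read-out lower numbers stand for stronger inhibition of growth and higher numbers for weaker inhibition of growth:
- Compound 1 `O=S(=O)(/C=C/c1ccc(Br)cc1)Cc1ccc(Nc2ncnc3ccccc23)cc1`: > 100000 nM (a limit)
- Compound 2 `O=S(=O)(/C=C/c1ccc(Cl)c(Cl)c1)Cc1ccc(Nc2ncnc3ccc(Br)cc23)cc1`: > 100000 nM (a limit)

Compound 2 gives > 100000 nM, which is a limit and not a number. Both measured compounds share one reading, (the limit of > 100000 nM in this assay, at which 2 of the 2 values shown sit).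

Compound 3 `O=S(=O)(/C=C/c1ccc(Br)cc1)Cc1ccc(Nc2ncnc3ccc(Br)cc23)cc1` carries 4-bromophenyl in place of 3,4-dichlorophenyl on a double-bonded chain carbon bound to a double-bonded chain carbon.

Compound 1 also carries 4-bromophenyl, and its > 100000 nM is likewise a limit. No step beyond the scatter is therefore expected in this assay.

The expected change is a number no higher from compound 2 to compound 3 (the limit leaves the size open).

Compound 3 is estimated at 100000 nM, with an expected range from 50000 nM to 200000 nM.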

Compound 3, concentration for 50% growth inhibition: 11000 nM
For compound 3 the middle estimate is 9.1-fold (0.96 log units) above the measured one, and the stated range ends above it.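

In this assay, 4-bromophenyl in place of 3,4-dichlorophenyl gives an at least 9.0-fold lower number from compound 2 to compound 3 (0.95 log units; beyond the scatter), so the group at this place can bring a compound off the limit. Bromo in place of hydrogen on an aromatic carbon gives an at least 9.0-fold lower number from compound 1 to compound 3 (0.95 log units; beyond the scatter), so this second change matters too. Only compound 3 carries both bromines, while compound 1 and compound 2 each stay at a limit: the limit of > 100000 nM in this assay, at which 2 of the 3 values shown sit.

On these data alone, the full size of both steps stays open, as each starts from a limit. As far as these compounds go, whether 4-methoxyphenyl or 4-aminophenyl at this place would match 4-bromophenyl also stays open.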